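Hydroxy in Place of Fluoro: What to Expect

This account rests on a few compounds, and the source may have more. Where it says the series, first, only, none or still open, it means among the compounds named here.

Of the compounds shown here, three built on one shared core have been measured in a functional assay on A549 cells (Homo sapiens) for inhibition; on this read-out lower numbers stand for stronger inhibition of growth and higher numbers for weaker inhibition of growth. Compound 1 `COc1cc(/C=C/c2ccc(S(N)(=O)=O)cc2)cc(OC)c1` gives 20700 nM. For the measured compounds named here, compound 2 `COc1cccc(/C=C/c2ccc(S(N)(=O)=O)cc2)c1` gives 11000 nM, and the single one-place comparison among the measured compounds is a 1.9-fold lower number from compound 1 to compound 2 (0.27 log units; within the scatter). Compound 3 `NS(=O)(=O)c1ccc(/C=C/c2ccc(F)cc2)cc1` gives 8930 nM; this is the lowest of the three numbers, yet its gap to compound 2 lies within the scatter, and only its gap to compound 1 lies beyond it.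

Compound 4 `NS(=O)(=O)c1ccc(/C=C/c2ccc(O)cc2)cc1` has not yet been measured. It differs from compound 3 by hydroxy in place of fluoro on an aromatic carbon. Going by the values given here, no measured step involves either a fluoro or a hydroxy; the one measured step, hydrogen in place of methoxy, is a different kind of change and stayed within the scatter, so it offers little guidance here. Among the compounds with values here, with no bearing step, the change a 1.0-fold higher number from compound 3 to compound 4 (0.00 log units; within the scatter) is expected to stay small in this assay. Compound 4 is estimated at 9000 nM, within a range from 3000 nM to 30000 nM.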

Compound 4, concentration for 50% growth inhibition: 13900 nM
The estimate for compound 4 lay 1.5-fold (0.19 log units) below the measured number; measured number inside the range.
By their numbers in this assay, from the lowest: compounds 3, 2, 4 and 1 (each within the scatter of the next, the first and the last beyond it).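

For the compounds shown here, at this place, on an aromatic carbon para to a large group, hydroxy in place of fluoro is the first change measured, and in this assay it gives a 1.6-fold higher number from compound 3 to compound 4 (0.19 log units; within the scatter) and so does not clearly separate the two groups. Hydroxy brings one hydrogen-bond donor and one hydrogen-bond acceptor where fluoro has none, yet this difference in the counts comes with a step that stays within the usual scatter of repeated measurements. No measurement is available that could explain the size of this step.

Going by these compounds, whether a larger step could arise here remains open, for instance with an amine or a carboxylic acid in the same place. Also open, on these data alone, is whether hydroxy in place of fluoro would behave the same way on an aromatic carbon elsewhere on the shared core.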